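The source may report more compounds than this note shows. Statements on the series, on what has been measured and on what is new or still open speak of the compounds shown alone.

Compound 1 `Cc1ccc(S(=O)(=O)c2nc3ccccc3nc2Nc2cccc(N)c2)cc1` and compound 3 `COc1ccc(S(=O)(=O)c2nc3ccccc3nc2Nc2cccc(N)c2)cc1` share a core and differ in a single group: methoxy in place of methyl on an aromatic carbon. In a functional assay on HCT-116 cells (Homo sapiens) for cytotoxicity, read by MTT assay, with a stated time of 72 h (on this read-out lower numbers stand for stronger inhibition and higher numbers for weaker inhibition), compound 1 gives 2390 nM, and compound 3 gives 3710 nM; the step between them, a 1.6-fold higher number from compound 1 to compound 3 (0.19 log units; within the scatter), stays within the usual scatter of repeated measurements, so the two numbers are best read as alike. Compound 2 `Cc1ccc(S(=O)(=O)c2nc3ccccc3nc2Nc2ccc(F)cc2)cc1` is compound 1 with a different group on the nitrogen: 4-fluorophenyl in place of 3-aminophenyl on a nitrogen on an aromatic ring. In this assay compound 2 gives 10500 nM, a weaker result, and the step of a 4.4-fold higher number from compound 1 to compound 2 (0.64 log units; beyond the scatter) lies beyond the scatter. Compound 4 `COc1ccc(S(=O)(=O)c2nc3ccccc3nc2Nc2ccc(F)cc2)cc1` has not yet been measured. It carries the same change relative to compound 3: 4-fluorophenyl in place of 3-aminophenyl on a nitrogen on an aromatic ring. The surroundings of the place are worded identically in both cases, so this is the same change, made on a core that differs only by the group already described. The expected step is a 4.3-fold higher number from compound 3 to compound 4 (0.63 log units; beyond the scatter). Among the measured compounds shown here, that expectation rests on the one earlier instance of the change, a 4.4-fold higher number from compound 1 to compound 2 (0.64 log units; beyond the scatter), and on the core difference having stayed within the scatter, a 1.6-fold higher number from compound 1 to compound 3 (0.19 log units; within the scatter), which gives no reason to think the change would behave differently on the second core. For compound 4 the estimated value in this assay is 16000 nM, with a likely span from 7000 nM to 38000 nM. A single prior instance is a thin basis, and the measurement will show how well it holds.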

Compound 4, half-maximal inhibitory concentration: 2110 nM
Compound 4: the middle estimate sits 7.6-fold (0.88 log units) above what was measured; measured number below the stated range.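

In this assay, 4-fluorophenyl in place of 3-aminophenyl on the nitrogen does not behave the same way on the two cores: the weaker result seen on the core of compound 1 does not return on the core of compound 3, where the step is a 1.8-fold lower number from compound 3 to compound 4 (0.25 log units; within the scatter), and the two numbers are best read as alike: the same change on two cores in this assay, a 4.4-fold higher number (0.64 log units; beyond the scatter) from compound 1 to compound 2 and a 1.8-fold lower number (0.25 log units; within the scatter) from compound 3 to compound 4, 7.7-fold (0.89 log units) apart, beyond the scatter of two such steps. Read the other way round, the swap of methyl for methoxy, which made no clear difference with 3-aminophenyl on the nitrogen, gives a 5.0-fold lower number from compound 2 to compound 4 (0.70 log units; beyond the scatter) with 4-fluorophenyl there: the same change on two cores in this assay, a 1.6-fold higher number (0.19 log units; within the scatter) from compound 1 to compound 3 and a 5.0-fold lower number (0.70 log units; beyond the scatter) from compound 2 to compound 4, 7.7-fold (0.89 log units) apart, beyond the scatter of two such steps. So in these four compounds the effect of a change at one place depends on the group at the other, and a step measured on one core cannot simply be carried to the other, though this single set of four compounds does not show why, nor whether the same holds for other groups.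

The compounds shown leave open whether this dependence extends to other groups on the nitrogen, such as a plain phenyl or a pyridyl. They also leave open how chloro or ethoxy in place of methoxy on the aromatic carbon would pair with each of those groups.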